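Swapping a dimethylamino for a phenoxy on the pyridine arm

This account rests on a few compounds, and the source may have more. Where it says the series, first, only, none or still open, it means among the compounds named here.

The three measured compounds share one core. Compound 1 `CCCn1ccc2cc(OCc3cccnc3)cc(Cl)c2c1=O` gives 2510 nM in a functional assay on CHO cells for agonist activity at metabotropic glutamate receptor 2 (Homo sapiens), read by GTPgammaS binding; on this read-out higher numbers stand for an effect only at larger amounts of compound and lower numbers for an effect already at smaller amounts; compound 2 `CCCn1ccc2cc(OCCc3cccnc3)cc(Cl)c2c1=O` gives 794 nM; compound 3 `CCCn1ccc2cc(-c3ccc(N(C)C)nc3)cc(Cl)c2c1=O` gives 5010 nM. For the measured compounds named here, the one step between neighbours, a 3.2-fold lower number from compound 1 to compound 2 (0.50 log units; beyond the scatter), leaves compound 3 with the highest number of the three, within the scatter of compound 1 and beyond it only against compound 2. Compound 4 `CCCn1ccc2cc(-c3ccc(Oc4ccccc4)nc3)cc(Cl)c2c1=O` differs from compound 3 by phenoxy in place of dimethylamino on an aromatic carbon, next to the ring nitrogen and para to a large group. Going by the values given here, no measured step covers such a swap, and the step from compound 1 to compound 2 concerns a different arm. With nothing to guide a direction, the expected step of a 1.4-fold lower number from compound 3 to compound 4 (0.16 log units; within the scatter) is none beyond the scatter, and compound 4 is estimated at 3500 nM, between 900 nM and 14000 nM.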

Compound 4, half-maximal effective concentration: 501 nM
For compound 4 the middle estimate is 7.0-fold (0.84 log units) above the measured one; the measured number lies below the stated range.
By their numbers in this assay, from the lowest: compounds 4 and 2 (each within the scatter of the next); then compounds 1 and 3 (each within the scatter of the next).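

In this assay, for the compounds shown here, the group on the aromatic carbon next to the ring nitrogen clearly matters: phenoxy in place of dimethylamino gives a 10-fold lower number from compound 3 to compound 4 (1.00 log units; beyond the scatter), the first measured change at this position. So this carbon can carry a group with its own six-membered aromatic ring and still give a lower number. Nothing measured here explains why the number falls. On these data alone, it remains open whether the oxygen link or the added ring accounts for the step, and how a methoxy, benzyl or morpholine group would fare on this carbon.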